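The source may report more compounds than this note shows. Statements on the series, on what has been measured and on what is new or still open speak of the compounds shown alone.

Compound 1: `O=C(Nc1cccc(-n2cc(-c3ccncc3)c(-c3ccc(Cl)c(O)c3)n2)c1)Nc1ccc(Cl)c(Cl)c1`, 1910 nM
Compound 2: `COc1cc(-c2nn(-c3cccc(NC(=O)c4ccc(Cl)c(C(F)(F)F)c4)c3)cc2-c2ccncc2)ccc1Cl`, 20400 nM

Of the compounds shown here, two have so far been tested in a functional assay on TK-10 cells (Homo sapiens) for inhibition, read by sulforhodamine B assay, with a stated time of 48 h; on this read-out higher numbers stand for weaker inhibition of growth and lower numbers for stronger inhibition of growth. Compound 1 gives 1910 nM in this assay. For the measured compounds named here, compound 2 gives 20400 nM in this assay, the highest of the two numbers; its only neighbour, compound 1, lies well below it, a gap beyond the usual scatter, so compound 2 is the weaker inhibitor of growth of the pair.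

Compound 3 `COc1cc(-c2nn(-c3cccc(NC(=O)Nc4cccc(C(F)(F)F)c4)c3)cc2-c2ccncc2)ccc1Cl` has not yet been measured. It differs from compound 2 in one place: (3-(trifluoromethyl)phenyl)amino in place of 4-chloro-3-(trifluoromethyl)phenyl on a carbonyl carbon. Going by the values given here, no step between measured compounds isolates this change, so its effect can only be guessed. The two measured values show that another compound built on the shared core, compound 1, reaches a far lower number than compound 2, which suggests that room for stronger inhibition of growth exists. The expected step from compound 2 to compound 3 is a modest move toward a lower number, a 2.6-fold lower number from compound 2 to compound 3 (0.41 log units; beyond the scatter), with much uncertainty. For compound 3 the estimate in this assay is 8000 nM, within a range from 2000 nM to 30000 nM.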

Compound 3, concentration for 50% growth inhibition: 1310 nM
Beside the measured number, compound 3's estimate is 6.1-fold (0.79 log units) above it; the measured number lies below the stated range.
By their numbers in this assay, from the lowest: compounds 3 and 1 (each within the scatter of the next); then compound 2.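

In this assay the swap on the carbonyl carbon gives a 16-fold lower number from compound 2 to compound 3 (1.19 log units; beyond the scatter), so what this place carries can move the number well beyond the usual scatter. The swap is really two edits made together: the chlorine leaves the aromatic ring, and an amino nitrogen with its hydrogen-bond donor enters on the carbonyl carbon, while the count of heavy atoms in the group stays the same and the trifluoromethyl group stays on the ring. For the compounds shown here, nothing measured so far gives a reason for this step, and the one step cannot show how much each of the two edits contributes.

Still open, from the compounds shown here alone, is what each edit does alone, which would take one compound that keeps the chlorine on the ring alongside the new amino nitrogen and another that lacks the chlorine but has no such nitrogen. Also open, going by these compounds, is whether the nitrogen itself matters, or whether an oxygen atom or a methylene group in its place on the carbonyl carbon would give a similar number.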